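Chain-end acetate variant of the lactone series

The source may report more compounds than this note shows. Statements on the series, on what has been measured and on what is new or still open speak of the compounds shown alone.

compound 1 `COCCCCCCCCCCCCCCC/C=C1\CC(CO)(COC(=O)C(C)(C)C)OC1=O` — in a functional assay on NCI-H322 cells (Homo sapiens) for antiproliferative activity (on this read-out higher numbers stand for weaker inhibition of growth and lower numbers for stronger inhibition of growth), compound 1 gives > 10 ug/mL, a limit.
compound 2 `CC(C)(C)C(=O)OCC1(CO)C/C(=C/CCCCCCCCCCCCCCC=O)C(=O)O1` — in this assay compound 2 gives > 10 ug/mL, also a limit.
compound 3 `CCCCCOCCCCCCC/C=C1\CC(CO)(COC(=O)C(C)(C)C)OC1=O` — in this assay compound 3 gives 9.52 ug/mL.

Going by the values given here, compound 3 is thus the only member of the set with a number; the other two values stop at the limit of > 10 ug/mL in this assay, at which 2 of the 3 values shown sit, so compound 3 stands alone and cannot be ranked against them. Among the compounds with values here, the single step that can be sized, an at least 1.0-fold lower number from compound 1 to compound 3 (0.02 log units; that floor lies within the scatter), lies within the scatter, so the shortening of the ether chain brought no change that can be trusted.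

Compound 4 `CC(=O)OCCCCCCCCCCCCCCC/C=C1\CC(CO)(COC(=O)C(C)(C)C)OC1=O` differs from compound 3 by 8-acetoxyoctyl in place of pentyloxy on a saturated chain carbon, seven bonds along the chain from a double-bonded chain carbon. Within the data shown here, the only step that bears on this change is the one from compound 1 to compound 3, and it was flat. The 8-acetoxyoctyl chain brings compound 4 back to the length of compound 1, which gave only a limit. No step beyond the scatter is therefore expected in this assay, and compound 4 is estimated at 12 ug/mL (range 5 ug/mL to 30 ug/mL), a step of a 1.3-fold higher number from compound 3 to compound 4 (0.10 log units; within the scatter), with a fair chance that the value is again reported as a limit.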

Compound 4, concentration for 50% growth inhibition: > 10 ug/mL
Compound 4: a limit, no number; the forecaster's own chance of this, stated with the estimate: 60%; the middle value lies beyond the limit too.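

Exchanging pentyloxy for 8-acetoxyoctyl gives an at least 1.0-fold higher number from compound 3 to compound 4 (0.02 log units; that floor lies within the scatter), so in this assay the larger ester-ended chain adds no readable change to compound 3. The step from compound 1 to compound 4, acetyl in place of methyl on an oxygen on a saturated carbon, cannot be read, as both values are limits. The chain-end acetate therefore joins the other long-chain values at one end of the read-out: the limit of > 10 ug/mL in this assay, at which 3 of the 4 values shown sit.

From the compounds shown here alone, whether acetyl and methyl differ at this oxygen remains open, as does whether any long-chain member would give a true number. A chain-end hydroxyl, amine or carboxylic acid could address both questions.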